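Ethynyl in place of bromo: working notes on the series

This account rests on a few compounds, and the source may have more. Where it says the series, first, only, none or still open, it means among the compounds named here.

Among the measured compounds shown here, in a functional assay on SK-OV-3 cells (Homo sapiens) for antiproliferative activity, read by MTT assay, with a stated time of 72 h (on this read-out lower numbers stand for stronger inhibition and higher numbers for weaker inhibition), compound 1 (`O=C(CCc1cccc2c1B(O)OC2)Nc1ccc(I)cc1`) gives 51000 nM and compound 2 (`O=C(CCc1cccc2c1B(O)OC2)Nc1cccc(Br)c1`) gives 540 nM, the lower of the two numbers so far. For the measured compounds named here, the only measured step, a 94-fold lower number from compound 1 to compound 2 (1.98 log units; beyond the scatter), is large and beyond the scatter. Going by the values given here, that step changes the halogen and its place together, so it cannot separate the two, and no measured step covers an ethynyl group. Compound 3 (`C#Cc1cccc(NC(=O)CCc2cccc3c2B(O)OC3)c1`) follows, with ethynyl in place of bromo on an aromatic carbon, meta to a large group. The place of the group stays the same, so a modest rise in this assay is expected, with a wide range given the size of a 94-fold lower number from compound 1 to compound 2 (1.98 log units; beyond the scatter). The estimated change is a 1.7-fold higher number from compound 2 to compound 3 (0.22 log units; within the scatter). For compound 3 the expected value is 900 nM, with an estimated range of 200 nM to 5000 nM.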

Compound 3, half-maximal inhibitory concentration: 980 nM
For compound 3 the middle estimate is 1.1-fold (0.04 log units) below the measured one; low and high end bracket the measured number.
By their numbers in this assay, from the lowest: compounds 2 and 3 (each within the scatter of the next); then compound 1.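

With the place held fixed, the exchange of bromo for ethynyl on this aromatic carbon, meta to a large group, gives in this assay a 1.8-fold higher number from compound 2 to compound 3 (0.26 log units; within the scatter), so this step, unlike the earlier one, isolates a change of group alone. Among the compounds shown here, at this place, a bromo of 1 heavy atom and an ethynyl of 2 heavy atoms with 1 triple bond outside aromatic rings cannot be told apart on this read-out, and the earlier compounds could not show this. Nothing available bears on why the two groups read alike.

Still unresolved is whether the halogen or its place accounts for a 94-fold lower number from compound 1 to compound 2 (1.98 log units; beyond the scatter) on the earlier step. The compounds shown also leave open how an amine or a carboxylic acid on this same aromatic carbon would read in this assay on the shared core.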